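Ring Size on the Nitrogen Substituent and Receptor Activation

A few compounds are considered here, and "the series" means these few. Any claim that something is new, unique, unknown or untested is made for them only; others in the source may bear on it.

Three compounds share one core and differ only in the group on an aromatic nitrogen. In an assay on Huh-7 cells for agonist activity at Bile acid receptor (Homo sapiens), read by a luciferase reporter (on this read-out higher numbers stand for an effect only at larger amounts of compound and lower numbers for an effect already at smaller amounts), compound 1 `CC(C)c1onc(-c2c(Cl)cccc2Cl)c1COc1ccc(-c2nc3ccc(C(=O)O)cc3n2Cc2ccc(F)cc2)cc1` gives 3.31 nM, compound 2 `CCCC(CCC)n1c(-c2ccc(OCc3c(-c4c(Cl)cccc4Cl)noc3C(C)C)cc2)nc2ccc(C(=O)O)cc21` gives 1.8 nM, and compound 3 `CC(C)c1onc(-c2c(Cl)cccc2Cl)c1COc1ccc(-c2nc3ccc(C(=O)O)cc3n2CC2CC2)cc1` gives 19.4 nM, the highest of the three, so compound 3 is the weakest of this set. From compound 1 to compound 2 the step is a 1.8-fold lower number from compound 1 to compound 2 (0.26 log units; within the scatter), whereas a 5.9-fold higher number from compound 1 to compound 3 (0.77 log units; beyond the scatter) and an 11-fold higher number from compound 2 to compound 3 (1.03 log units; beyond the scatter) both stand beyond the scatter. Compound 4 `CC(C)c1onc(-c2c(Cl)cccc2Cl)c1COc1ccc(-c2nc3ccc(C(=O)O)cc3n2C2CCCCCC2)cc1` carries cycloheptyl in place of cyclopropylmethyl on an aromatic nitrogen. Because an 11-fold higher number from compound 2 to compound 3 (1.03 log units; beyond the scatter) accompanied the loss of 1-propylbutyl, cycloheptyl is expected to move the number in this assay back down, roughly a 5.5-fold lower number from compound 3 to compound 4 (0.74 log units; beyond the scatter). Compound 4 is therefore estimated at 3.5 nM, with a range from 1.2 nM to 10 nM.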

Compound 4, half-maximal effective concentration: 14.8 nM
The estimate for compound 4 lay 4.2-fold (0.63 log units) below the measured number; measured number outside the range, above it.
By their numbers in this assay, from the lowest: compounds 2 and 1 (each within the scatter of the next); then compounds 4 and 3 (each within the scatter of the next).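

With a 1.3-fold lower number from compound 3 to compound 4 (0.12 log units; within the scatter) cyclopropylmethyl and cycloheptyl cannot be told apart at this aromatic nitrogen, although the carbon count rises and a three-membered ring gives way to a seven-membered one. More carbon in a ring is therefore not enough here to match 1-propylbutyl or 4-fluorobenzyl, as an 8.2-fold higher number from compound 2 to compound 4 (0.91 log units; beyond the scatter) and a 4.5-fold higher number from compound 1 to compound 4 (0.65 log units; beyond the scatter) show. Nothing measured here explains these gaps. Cyclohexyl, isopropyl and unsubstituted benzyl at this nitrogen remain open. So does whether an open chain or an aromatic ring is what separates compounds 1 and 2 from compounds 3 and 4.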